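Bromo for nitro on two cores: growth inhibition notes

This account rests on a few compounds, and the source may have more. Where it says the series, first, only, none or still open, it means among the compounds named here.

Of the compounds shown here, three have been measured in a functional assay on SF-268 cells (Homo sapiens) for inhibition, read by sulforhodamine B assay, with a stated time of 48 h; on this read-out higher numbers stand for weaker inhibition of growth and lower numbers for stronger inhibition of growth. Compound 1 `N#CCC1=NN=C(c2ccc([N+](=O)[O-])cc2)C(CC(=O)c2ccc([N+](=O)[O-])cc2)O1` gives 2000 nM in this assay. Compound 2 `N#CCC1=C(C#N)CC(c2ccc([N+](=O)[O-])cc2)=C(CC(=O)c2ccc([N+](=O)[O-])cc2)O1` gives 5 nM, and compound 3 `N#CCC1=C(C#N)CC(c2ccc([N+](=O)[O-])cc2)=C(CC(=O)c2ccc(Br)cc2)O1` gives 2800 nM. The difference between the core of compound 1 and the core of compound 2 is not broken down here. Within the second core, compound 3 differs from compound 2 by bromo in place of nitro on an aromatic carbon, and this change made a 560-fold higher number from compound 2 to compound 3 (2.75 log units; beyond the scatter). Compound 1 and compound 3 lie within the usual scatter of each other, so no order between them can be read from this assay.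

Compound 4 `N#CCC1=NN=C(c2ccc([N+](=O)[O-])cc2)C(CC(=O)c2ccc(Br)cc2)O1` has not been measured. It differs from compound 1 by bromo in place of nitro on an aromatic carbon; this is the same change, at a place described in the same words, as the one from compound 2 to compound 3, and it occurs twice among the compounds shown. From the compounds shown here alone, a step in the same direction is expected, but a smaller one than the measured step, because compound 1 already stands at 2000 nM and the change is carried on a different core whose response to it is untested. Compound 4 is therefore expected near 15000 nM, with a range from 3000 nM to 200000 nM. This amounts to an expected step of a 7.5-fold higher number from compound 1 to compound 4 (0.88 log units; beyond the scatter). The chance that this assay returns only a limit for compound 4 is judged to be substantial.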

Compound 4, concentration for 50% growth inhibition: 16500 nM
Estimate against measurement, compound 4: 1.1-fold (0.04 log units) below; measured number inside the range.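

In this assay, the change from 4-nitrophenyl to 4-bromophenyl on the core of compound 1 gives an 8.3-fold higher number from compound 1 to compound 4 (0.92 log units; beyond the scatter), so the number rises on this core as it does on the core of compound 2. The direction of the change therefore carries from one core to the other in the two pairs available, but its size does not: the same change on two cores in this assay, a 560-fold higher number (2.75 log units; beyond the scatter) from compound 2 to compound 3 and an 8.3-fold higher number (0.92 log units; beyond the scatter) from compound 1 to compound 4, 68-fold (1.83 log units) apart, beyond the scatter of two such steps. This shows that the size of the step on one core cannot be used directly as the size on the other, but two pairs do not establish a general rule for the series, and they do not show which feature of the two cores accounts for the gap or how the change would behave on any third core.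

From the compounds shown here alone, only nitro and bromo appear at this place, so it remains open whether a chloro, a nitrile, an amine or a carboxylic acid there would follow the nitro compounds or the bromo compounds on either core. The other 4-nitrophenyl group is the same in all four compounds shown, so the effect of replacing it with bromo, or with an amine, also remains open on both cores.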